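Chlorinated sulfonamide piperidines: an isobutyl addition

This account rests on a few compounds, and the source may have more. Where it says the series, first, only, none or still open, it means among the compounds named here.

Measured so far, in a functional assay on WiDr cells (Homo sapiens) for antiproliferative activity, read by sulforhodamine B assay, with a stated time of 48 h; on this read-out lower numbers stand for stronger inhibition of growth and higher numbers for weaker inhibition of growth:
compound 1 `Cc1ccc(S(=O)(=O)N2CCC(Cl)CC2)cc1` gives > 100000 nM, a limit of the assay and not a number.
compound 2 `Cc1ccc(S(=O)(=O)N2CC=C(Cl)CC2)cc1` gives > 100000 nM, likewise a limit and not a number.

Among the compounds with values here, compound 2 therefore stands nowhere on a numerical scale: both values shown sit at the limit of > 100000 nM in this assay, at which 2 of the 2 values shown sit, so there is no measured step in this assay and no size of effect to lean on. Compound 3 `Cc1ccc(S(=O)(=O)N2CCC(Cl)=CC2CC(C)C)cc1` differs from compound 2 by isobutyl in place of hydrogen on a saturated ring carbon, while the chloro group and the sulfonamide are kept. Within the data shown here, with no step between measured compounds, no direction can be read from the data; the only evidence is that two close relatives of compound 3 show no measurable growth inhibition. The expected change is an at least 1.2-fold lower number from compound 2 to compound 3 (0.09 log units; that floor lies within the scatter), that is, at most a modest movement toward a measurable number. Compound 3 is accordingly estimated at 80000 nM, in the range 20000 nM to 300000 nM, with a fair chance that this assay again reports only a limit.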

Compound 3, concentration for 50% growth inhibition: 21000 nM
The estimate for compound 3 lay 3.8-fold (0.58 log units) above the measured number; measured number inside the range.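

In this assay, isobutyl in place of hydrogen on a saturated ring carbon, next to the ring nitrogen, gives an at least 4.7-fold lower number from compound 2 to compound 3 (0.67 log units; beyond the scatter), and this is the only change shown that yields a number rather than a limit. This ring position therefore accepts a group, and substitution there, with the chloro group and the sulfonamide kept, can register growth inhibition where the unsubstituted compound 2 does not. The step is a floor and not a full size, because its starting point is a limit: the limit of > 100000 nM in this assay, at which 2 of the 3 values shown sit.

As far as these compounds go, it remains open whether the effect belongs to isobutyl specifically or would also appear with a methyl group, a longer chain, a phenyl ring or an amine at the same ring carbon. From the compounds shown here alone, it is also open whether isobutyl would give a number on the core of compound 1.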